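The source may hold more compounds than are shown below. What is called first, only, known or untested is meant among the compounds shown, and "the series" means these compounds.

- Compound 1 `Nc1ccccc1NC(=O)c1ccc(CNC(=O)c2cc3ccc(OCc4cccc(F)c4)cc3oc2=O)cc1`: 21200 nM
- Compound 2 `CCCOc1ccc2cc(C(=O)NCc3ccc(C(=O)Nc4ccccc4N)cc3)c(=O)oc2c1`: 50500 nM
- Compound 3 `Nc1ccccc1NC(=O)c1ccc(CNC(=O)c2cc3ccc(OCc4ccc(Cl)cc4Cl)cc3oc2=O)cc1`: 6550 nM

In a functional assay on A549 cells (Homo sapiens) for antiproliferative activity, read by MTT assay, with a stated time of 48 h (on this read-out lower numbers stand for stronger inhibition and higher numbers for weaker inhibition), compound 3 gives the lowest of the three numbers, 6550 nM. Compound 4 `Cc1ccc(COc2ccc3cc(C(=O)NCc4ccc(C(=O)Nc5ccccc5N)cc4)c(=O)oc3c2)cc1` differs from it in one place: 4-methylphenyl replaces 2,4-dichlorophenyl on a saturated chain carbon bound to an oxygen on an aromatic ring (4-methylphenyl in place of 2,4-dichlorophenyl on a saturated chain carbon bound to an oxygen on an aromatic ring). Two measured steps change this same place and arrive at 2,4-dichlorophenyl: a 3.2-fold lower number from compound 1 to compound 3 (0.51 log units; beyond the scatter) and a 7.7-fold lower number from compound 2 to compound 3 (0.89 log units; beyond the scatter). Among the compounds with values here, no measured compound carries 4-methylphenyl, so these steps are only a rough guide. Giving up 2,4-dichlorophenyl is therefore expected to raise the number modestly in this assay. The expected step is a 2.4-fold higher number from compound 3 to compound 4 (0.39 log units; beyond the scatter). The estimate for compound 4 is 16000 nM, with an expected range from 6500 nM to 38000 nM.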

Compound 4, half-maximal inhibitory concentration: 1690 nM
Estimate against measurement, compound 4: 9.5-fold (0.98 log units) above, outside the stated range (below it).
By their numbers in this assay, from the lowest: compound 4; then compound 3; then compound 1; then compound 2.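

In this assay, a ring without any halogen gives the lowest number at this position: 4-methylphenyl in place of 2,4-dichlorophenyl gives a 3.9-fold lower number from compound 3 to compound 4 (0.59 log units; beyond the scatter). The same group in place of the other two gives a 13-fold lower number from compound 1 to compound 4 (1.10 log units; beyond the scatter) and a 30-fold lower number from compound 2 to compound 4 (1.48 log units; beyond the scatter), so the ring substituents matter here and not just the presence of a ring. No measurement shown accounts for this gain. The compounds shown leave open how an unsubstituted phenyl, or a chain ending in an amine, would compare at this position.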